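The compounds below may be only part of what the source reports. "The series", "measured", "known", "first", "only" and "open" are said of these compounds alone.

Of the compounds shown here, three carry a measured number so far. Going by the values given here, in a functional assay on the whole organism with Mus musculus as the target, with a stated time of 90 min, at a dose of 25 umol/kg by the oral route (on this read-out lower numbers stand for a weaker effect and higher numbers for a stronger effect at the one dose given), compound 1 `CCOC(=O)CN(c1nc(Cl)nc2c1ncn2C1CCCCO1)C1CC1` gives 13%, and compound 2 `O=C(O)CN(c1nc(Cl)nc2c1ncn2C1CCCCO1)C1CC1` gives 8.22%; the step of a number 4.8 percentage points lower from compound 1 to compound 2 (within the scatter) is the only one measured between close neighbours. Compound 3 `C[C@H](NC(=O)CN(c1nc(Cl)nc2c1ncn2C1CCCCO1)C1CC1)C(=O)OCc1ccccc1` gives 32.1% in this assay, the highest of the three numbers; compound 1 is the nearest and compound 2 the furthest, both beyond the scatter below it. Compound 4 `N=C(N)NCCC[C@H](NC(=O)CN(c1nc(Cl)nc2c1ncn2C1CCCCO1)C1CC1)C(=O)OCc1ccccc1` is not yet measured. It differs from compound 3 by a group of 6 heavy atoms (3 carbon, 3 nitrogen; no ring) in place of a hydrogen atom, on a saturated chain carbon, two bonds along the chain from an amide-type nitrogen and a carbonyl carbon. Among the compounds with values here, none of the measured steps bears on this change: the one step measured, from compound 1 to compound 2, concerns the oxygen next to a carbonyl group and not the saturated chain carbon changed here, and it lay within the scatter. Within the data shown here, with no step of this kind measured, no direction beyond the scatter can be argued, and the expected step of a number 2.1 percentage points lower from compound 3 to compound 4 (within the scatter) is set at about none. Compound 4 is therefore estimated at 30% in this assay, within a wide range from 10% to 55%.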

Compound 4, a percentage reported as activity, at one dose (the size of the read-out at that dose, not a potency): 61.6%
Compound 4: the middle estimate sits 31.6 percentage points below what was measured; measured number outside the range, above it.
By their numbers in this assay, from the lowest: compounds 2 and 1 (each within the scatter of the next); then compound 3; then compound 4.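

In this assay the saturated chain carbon two bonds along the chain from an amide-type nitrogen and a carbonyl carbon proves open to change, with a group of 6 heavy atoms (3 carbon, 3 nitrogen; no ring) in place of a hydrogen atom giving a number 29.5 percentage points higher from compound 3 to compound 4 (beyond the scatter). The one earlier step between close neighbours, at another place, stayed within the scatter, so this is the first change shown to move the read-out beyond it. Nothing available explains this gain.

Going by these compounds, whether the gain needs the whole group remains open: a simple amine at the end of the same chain, or a plain alkyl chain on this carbon, would separate the end group from the chain carrying it. Also open, on these data alone, is whether the step holds with a carboxylic acid in place of the benzyl ester.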